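The compounds below may be only part of what the source reports. "The series", "measured", "known", "first", "only" and "open" are said of these compounds alone.

In an ADME assay on L929 cells (Mus musculus) for cytotoxicity, read by resazurin assay, with a stated time of 48 h (on this read-out higher numbers stand for lower toxicity in this test and lower numbers for higher toxicity in this test), compound 1 `COC(=O)CCn1c2ccc([N+](=O)[O-])cc2c(=O)n1Cc1ccccc1` gives > 256000 nM as its read-out, which is a limit of the assay and not a number. Among the measured compounds shown here, compound 2 `CCOC(=O)CCCn1c2ccc([N+](=O)[O-])cc2c(=O)n1Cc1ccccc1` gives 78100 nM as the only true number so far. For the measured compounds named here, the one measured step is an at least 3.2-fold lower number from compound 1 to compound 2 (0.51 log units; beyond the scatter) and it concerns the chain, not the change at hand. Compound 3 `CN(C)C(=O)CCCn1c2ccc([N+](=O)[O-])cc2c(=O)n1Cc1ccccc1` carries dimethylamino in place of ethoxy on a carbonyl carbon, with dimethylamino in place of ethoxy on a carbonyl carbon as the count. Going by the values given here, no measured step covers this swap, so the size of an at least 3.2-fold lower number from compound 1 to compound 2 (0.51 log units; beyond the scatter) serves only as a rough ceiling. A small move towards a higher number, meaning lower toxicity in this test, is expected, and the estimated change is a 1.5-fold higher number from compound 2 to compound 3 (0.19 log units; within the scatter) in this assay for now. For compound 3 the estimated value is 120000 nM with an expected range from 45000 nM to 256000 nM for this read-out.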

Compound 3, concentration lethal to 50% of the cells: > 256000 nM
Compound 3: only a limit was reported; the forecaster's own chance of this, stated with the estimate: 25%; middle value at least 2.1-fold (0.32 log units) away from the limit.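

At this position, dimethylamino in place of ethoxy on a carbonyl carbon gives, in this assay, an at least 3.2-fold higher number from compound 2 to compound 3 (0.51 log units; beyond the scatter). With the chain held constant, the number seen for compound 2 therefore depends on the group on the carbonyl carbon, which the earlier chain step could not show. The read-out of compound 3 is a limit of the assay and not a number, so the size of this change has no upper bound here: the limit of > 256000 nM in this assay, at which 2 of the 3 values shown sit.

The step between compound 1 and compound 3 cannot be read: both values are limits. Still open, as far as these compounds go, is whether a carboxylic acid or a primary amide on this carbonyl carbon would also reach the limit, and whether a longer chain ending in dimethylcarbamoyl would give a true number.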